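This account rests on a few compounds, and the source may have more. Where it says the series, first, only, none or still open, it means among the compounds named here.

Compounds measured in a functional assay on PC-3 cells (Homo sapiens) for inhibition, read by MTT assay, with stated times of 18 h and 4 h; on this read-out higher numbers stand for weaker inhibition and lower numbers for stronger inhibition:
compound 1 `CCCCCCOP(=O)(O)OCCSC(=S)N1CCCCCC1` — > 100000 nM, a limit of the assay.
compound 2 `CCCCCCOP(=O)(O)OCCSC(=S)N1CCN(C)CC1` — > 100000 nM, a limit of the assay.

Compound 2 stands only at that limit in this assay, as does compound 1 (the limit of > 100000 nM in this assay, at which 2 of the 2 values shown sit). For the measured compounds named here, the one measured step, a step that the two limits leave unreadable from compound 1 to compound 2, is unreadable between two limits and does not concern the hexyl chain. Compound 3 `CCCCCCCCCCCCCCCCOP(=O)(O)OCCSC(=S)N1CCN(C)CC1` differs from compound 2 by decyl in place of hydrogen on a saturated chain carbon, six bonds along the chain from an oxygen on an unsaturated carbon. No measured step bears on this change, so the expected step of an at least 5.0-fold lower number from compound 2 to compound 3 (0.69 log units; beyond the scatter) rests on nothing shown and is uncertain; compound 3 is estimated at 20000 nM, within 3000 nM to 100000 nM.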

Compound 3, half-maximal inhibitory concentration: 95200 nM
Compound 3: middle estimate off by 4.8-fold (0.68 log units), on the low side, within the range that was stated.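

Decyl in place of hydrogen, on a saturated chain carbon, six bonds along the chain from an oxygen on an unsaturated carbon, gives the first step of the series with a readable floor, an at least 1.0-fold lower number from compound 2 to compound 3 (0.02 log units; that floor lies within the scatter), in this assay. For the compounds shown here, its true size stays unknown, but compound 3 gives the series its only actual number, 95200 nM. The read-out still offers little to compare: the limit of > 100000 nM in this assay, at which 2 of the 3 values shown sit.

Open, going by these compounds, is how a longer chain, or an amine or carboxylic acid at the chain end, would read in this assay. Also open, on these data alone, is whether azepan-1-yl on the thiocarbonyl carbon would differ from 4-methylpiperazin-1-yl when carried with the longer chain of compound 3.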